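Vero cytotoxicity notes: nitrile analogue of compound 1

This account rests on a few compounds, and the source may have more. Where it says the series, first, only, none or still open, it means among the compounds named here.

Measured so far in an ADME assay on Vero cells (Chlorocebus sabaeus) for cytotoxicity, with a stated time of 72 h; on this read-out lower numbers stand for stronger inhibition and higher numbers for weaker inhibition:
compound 1 `O=[N+]([O-])c1cn2c(n1)OC[C@@H](OCc1ccc(-c3ccc(OC(F)(F)F)cc3)cc1)C2`: > 128000 nM
compound 2 `O=[N+]([O-])c1cn2c(n1)OC[C@@H](OCc1ccc(-c3ccc(OC(F)(F)F)cc3)c(Cl)c1)C2`: > 128000 nM

Compound 1 stands only as a limit in this assay: the value > 128000 nM is a limit of the assay and not a number. Compound 2 likewise gives > 128000 nM in this assay, again a limit. Going by the values given here, the one step that differs in a single place, a step that the two limits leave unreadable from compound 1 to compound 2, therefore cannot be sized; all that is known is the limit of > 128000 nM in this assay, at which 2 of the 2 values shown sit.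

Compound 3 `N#Cc1cc(-c2ccc(OC(F)(F)F)cc2)ccc1CO[C@@H]1COc2nc([N+](=O)[O-])cn2C1` differs from compound 1 by cyano in place of hydrogen on an aromatic carbon. Among the compounds with values here, the only measured change, chloro in place of hydrogen on an aromatic carbon, left the read-out at the limit in both cases, so no direction of change beyond the scatter can be inferred for compound 3 from the numbers in hand. The expectation for compound 3 is a step that the limit leaves unreadable from compound 1 to compound 3 that stays within the scatter, most likely again reported as a limit. Compound 3 is accordingly estimated at 150000 nM in this assay, within 70000 nM to 320000 nM.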

Compound 3, half-maximal inhibitory concentration: > 128000 nM
Compound 3: only a limit was reported; the forecaster's own chance of this, stated with the estimate: 85%; the middle value is on the limit's open side.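

In this assay compound 3 gives > 128000 nM, a limit of the assay and not a number. With compound 1 also reported only as a limit, no new step can be read from compound 1 to compound 3. The compounds shown leave open whether chloro or cyano in place of hydrogen on an aromatic carbon changes this read-out at all, as all that is known is: the limit of > 128000 nM in this assay, at which 3 of the 3 values shown sit.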